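A few compounds are considered here, and "the series" means these few. Any claim that something is new, unique, unknown or untested is made for them only; others in the source may bear on it.

Measured so far:
Compound 1 `C=CCOc1ccc2c(=O)c(-c3cc(OC)c(OC)cc3OC)coc2c1` gives 4750 nM in a functional assay on A-375 cells (Homo sapiens) for antiproliferative activity, read by MTT assay, with a stated time of 24 h; a higher number here means a weaker inhibitor, a lower number a stronger inhibitor.
Compound 2 `COc1cccc(C(=O)Oc2ccc3c(=O)c(-c4cc(OC)c(OC)cc4OC)coc3c2)c1` gives > 10000 nM, which is a limit of this assay rather than a number.
Compound 3 `COc1cc(OC)c(-c2coc3cc(OCc4ccc(F)cc4)ccc3c2=O)cc1OC` gives 1720 nM.

Compound 1 stands highest of the two numbers in this assay; its nearest neighbour is compound 3, reached by a 2.8-fold lower number from compound 1 to compound 3 (0.44 log units; beyond the scatter). Compound 2 sits at the limit of > 10000 nM in this assay, at which 1 of the 3 values shown sits, and offers no number.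

Compound 4 `COc1cc(OC)c(-c2coc3cc(OCc4ccccc4C(F)(F)F)ccc3c2=O)cc1OC` differs from compound 1 by 2-(trifluoromethyl)phenyl in place of vinyl on a saturated chain carbon bound to an oxygen on an aromatic ring. The step that bears most on it is a 2.8-fold lower number from compound 1 to compound 3 (0.44 log units; beyond the scatter), where a substituted phenyl also entered at the same place, with a modest gain; an at least 5.8-fold lower number from compound 2 to compound 3 (0.76 log units; beyond the scatter) points the same way for a benzyl ether. A modest lower number is therefore expected, a 2.4-fold lower number from compound 1 to compound 4 (0.38 log units; beyond the scatter). Compound 4 is thus estimated at 2000 nM, with a range from 900 nM to 4500 nM.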

Compound 4, half-maximal inhibitory concentration: > 10000 nM
Compound 4: a limit, no number; the forecaster's own chance of this, stated with the estimate: 5%; middle value at least 5.0-fold (0.69 log units) from the limit.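

The benzyl-type ether on this oxygen therefore does not bring a gain by itself: 2-(trifluoromethyl)phenyl in this place gives an at least 2.1-fold higher number from compound 1 to compound 4 (0.32 log units; beyond the scatter), and against 4-fluorophenyl gives an at least 5.8-fold higher number from compound 3 to compound 4 (0.76 log units; beyond the scatter). Compound 4 gives a limit in this assay rather than a number, the same limit as compound 2: the limit of > 10000 nM in this assay, at which 2 of the 4 values shown sit. The step between these two limits cannot be read.

Going by these compounds, what remains open is how an unsubstituted benzyl or a longer chain would fare on this oxygen. Also open, on these data alone, is whether the loss belongs to the trifluoromethyl group itself or to its place on the phenyl.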